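A few compounds are considered here, and "the series" means these few. Any claim that something is new, unique, unknown or untested is made for them only; others in the source may bear on it.

Measured compounds in this series:

compound 1, `Cc1cc(O)c(C2=NN(c3ccc(S(N)(=O)=O)cc3)C(c3ccccc3O)C2)cc1Cl`, which in a functional assay on SNB-75 cells (Homo sapiens) for antiproliferative activity, with a stated time of 48 h (on this read-out lower numbers stand for stronger inhibition of growth and higher numbers for weaker inhibition of growth), gives 13600 nM;
compound 2, `Cc1cc(O)c(C2=NN(c3ccc(S(N)(=O)=O)cc3)C(/C=C/c3ccccc3)C2)cc1Cl`, which in this assay gives 16100 nM.

Among the measured compounds shown here, compound 2 stands at the highest of the two numbers so far, but its only neighbour is compound 1, and the step of a 1.2-fold higher number from compound 1 to compound 2 (0.07 log units; within the scatter) is within the scatter, so the two cannot be placed in order.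

Compound 3 is `COc1ccc(C2CC(c3cc(Cl)c(C)cc3O)=NN2c2ccc(S(N)(=O)=O)cc2)c(OC)c1OC`. Relative to compound 2 the change is 2,3,4-trimethoxyphenyl in place of 2-phenylethenyl on a saturated ring carbon. For the measured compounds named here, the one measured step that bears on this change is the exchange at the same saturated ring carbon, a 1.2-fold higher number from compound 1 to compound 2 (0.07 log units; within the scatter), which did not move the number beyond the scatter. Nothing else in the series speaks to a trimethoxyphenyl group at that position. On that basis no step beyond the scatter is expected in this assay for this exchange either; the change from compound 2 to compound 3 is estimated as a 1.1-fold lower number from compound 2 to compound 3 (0.03 log units; within the scatter). For compound 3 the expected value is therefore 15000 nM, with a range from 5000 nM to 45000 nM.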

Compound 3, concentration for total growth inhibition: 28500 nM
For compound 3 the middle estimate is 1.9-fold (0.28 log units) below the measured one; the range from low to high includes it.
By their numbers in this assay, from the lowest: compounds 1, 2 and 3 (each within the scatter of the next, the first and the last beyond it).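

Among the compounds shown here, at the saturated ring carbon next to the ring nitrogen, this assay now gives the first step beyond the scatter: a 2.1-fold higher number from compound 1 to compound 3 (0.32 log units; beyond the scatter), modest in size, for 2,3,4-trimethoxyphenyl in place of 2-hydroxyphenyl. The exchange of 2-phenylethenyl for 2,3,4-trimethoxyphenyl stays within the scatter, at a 1.8-fold higher number from compound 2 to compound 3 (0.25 log units; within the scatter), so the group at this carbon can shift the number, but only slightly, and compound 2 cannot be separated from either of the other two. No measurement at hand bears on the reason for this step.

Whether the step needs all three methoxy groups stays open, since a phenyl ring with a single methoxy group is not among the compounds shown. Also open, on these data alone, is how a group of a different kind at this carbon, such as an amine or a carboxylic acid, would read in this assay.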